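A New Group on the Ring Nitrogen of Compound 3

The source may hold more compounds than are shown below. What is called first, only, known or untested is meant among the compounds shown, and "the series" means these compounds.

In an in vitro ADME assay on microsomes from liver (Homo sapiens) for pharmacokinetics, read by LC-MS, with a stated time of 10 min, tested at 1 uM (a higher number here means faster removal of the compound, a lower number slower removal), three compounds sharing one core have been measured. Compound 1 (`CCN1C[C@H](C(=O)Nc2ccc(Cl)cc2)[C@@H](c2ccc(/C=C/C(=O)Nc3ccccc3N)cc2)C1`) with ethyl on the amine nitrogen in a ring gives 12 mL/min/kg as its clearance. Compound 2 (`CC(C)(CO)N1C[C@H](C(=O)Nc2ccc(Cl)cc2)[C@@H](c2ccc(/C=C/C(=O)Nc3ccccc3N)cc2)C1`) with 1-(hydroxymethyl)-1-methylethyl there gives 12 mL/min/kg as its clearance. Compound 3 (`N#CCN1C[C@H](C(=O)Nc2ccc(Cl)cc2)[C@@H](c2ccc(/C=C/C(=O)Nc3ccccc3N)cc2)C1`) with cyanomethyl there gives 17 mL/min/kg and so stands within the usual scatter of both others.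

Compound 4 (`CCNC(=O)N1C[C@H](C(=O)Nc2ccc(Cl)cc2)[C@@H](c2ccc(/C=C/C(=O)Nc3ccccc3N)cc2)C1`) is still unmeasured. Within the data shown here, its single difference from compound 3 is ethylcarbamoyl in place of cyanomethyl on an amine nitrogen in a ring and no measured compound carries that group, so the guide is only loose. Among the measured compounds shown here, with no change at the digits printed from compound 1 to compound 2 (within the scatter) and a 1.4-fold higher number from compound 1 to compound 3 (0.15 log units; within the scatter) and a 1.4-fold higher number from compound 2 to compound 3 (0.15 log units; within the scatter) as the only measured steps at this nitrogen, no step beyond the scatter is expected in this assay for the new group. The estimated move is a 1.2-fold lower number from compound 3 to compound 4 (0.08 log units; within the scatter) and it is expected to stay inside the scatter. For compound 4 the estimated clearance is 14 mL/min/kg within an expected range from 8 mL/min/kg to 25 mL/min/kg in this read-out.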

Compound 4, clearance: 9 mL/min/kg
The estimate for compound 4 lay 1.6-fold (0.19 log units) above the measured number; measured number inside the range.
By their numbers in this assay, from the lowest: compounds 4, 1, 2 and 3 (each within the scatter of the next).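

In this assay ethylcarbamoyl on the amine nitrogen in the ring gives a 1.9-fold lower number from compound 3 to compound 4 (0.28 log units; within the scatter) and a 1.3-fold lower number from compound 2 to compound 4 (0.12 log units; within the scatter) and also a 1.3-fold lower number from compound 1 to compound 4 (0.12 log units; within the scatter) so every step to the new group stays inside the usual scatter. This is the first group shown at this nitrogen that holds a carbonyl, and with it the four groups in compounds 1, 2, 3 and 4 all read alike in clearance, so this position has tolerated each of these changes in this assay. Nothing on hand explains why these four groups read alike.

The compounds shown leave open whether a carboxylic acid, a sulfonamide or a longer chain on this nitrogen would give a step beyond the scatter. They also leave open whether ethylcarbamoyl would read the same way on a different core.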